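The source may hold more compounds than are shown below. What is called first, only, known or untested is meant among the compounds shown, and "the series" means these compounds.

Among the compounds with values here, compound 1 `CC#CC(CC(=O)O)c1ccc(OCC2COc3ccc(Cl)cc3O2)cc1` gives 100 nM in a functional assay on HEK293 cells for agonist activity at Free fatty acid receptor 1 (Homo sapiens), read by fluorescence and calcium flux, with a stated time of 10 min (on this read-out higher numbers stand for an effect only at larger amounts of compound and lower numbers for an effect already at smaller amounts), the lower of the two numbers known; compound 2 `O=C(O)CC1(c2ccc(OCC3COc4ccc(Cl)cc4O3)cc2)COC1` gives 8060 nM, and the step of an 81-fold higher number from compound 1 to compound 2 (1.91 log units; beyond the scatter) is the only one measured. Compound 3 `CC#C[C@H](CC(=O)O)c1ccc(OC[C@H]2COc3ccc(Cl)cc3O2)cc1` differs from compound 1 in this way: the two compounds have the same atoms and bonds; at least one stereo element is drawn with a configuration in one of them and without one in the other: 2 of 2 stereo elements differ; a stereocentre at a saturated chain carbon is drawn without a configuration in compound 1 and R in compound 3; a stereocentre at a saturated ring carbon is drawn without a configuration in compound 1 and S in compound 3. Within the data shown here, the one measured step concerns an exchange of groups and so does not bear on a change that fixes configuration alone; no measured pair shows what drawing both stereocentres does. Compound 3 is therefore expected to lie near compound 1, with the step of a 1.7-fold lower number from compound 1 to compound 3 (0.22 log units; within the scatter) judged within the scatter. The estimate for compound 3 is 60 nM, ranging from 15 nM to 400 nM.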

Compound 3, half-maximal effective concentration: 3400 nM
Beside the measured number, compound 3's estimate is 57-fold (1.75 log units) below it, outside the stated range (above it).
By their numbers in this assay, from the lowest: compound 1; then compound 3; then compound 2.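

With atoms and bonds unchanged, this assay still gives a 34-fold higher number from compound 1 to compound 3 (1.53 log units; beyond the scatter), so stereochemistry alone can produce a large step in this series, something the earlier exchange of groups could not show. The step can be traced to the stereocentres because of one thing only: the fact that one of compounds 1 and 3 is drawn with a defined configuration and the other without, at the place where they differ

Which of the two stereocentres accounts for the step stays open, as does the standing of the other configurations at the chain carbon and the ring carbon. Also open, going by these compounds, is how a primary amide in place of the carboxylic acid would behave at either configuration.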